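Swapping the tetrazole substituent in a biphenyl series

This account rests on a few compounds, and the source may have more. Where it says the series, first, only, none or still open, it means among the compounds named here.

Measured so far:
- Compound 1, `CC(C)(N)CC(=O)N[C@@H]1CCc2ccccc2N(Cc2ccc(-c3ccccc3C(=O)O)cc2)C1=O`: 3 uM
- Compound 2, `CC(C)(N)CC(=O)N[C@@H]1CCc2ccccc2N(Cc2ccc(-c3ccccc3-c3nnn(Cc4ccccc4)n3)cc2)C1=O`: 1 uM
- Compound 3, `Cn1nnnc1-c1ccccc1-c1ccc(CN2C(=O)[C@H](NC(=O)CC(C)(C)N)CCc3ccccc32)cc1`: 0.5 uM

In a functional assay (Pituitary gland cell) with Rattus norvegicus as the target (a higher number here means that more compound is needed for the effect, a lower number that less compound is needed), compound 3 gives the lowest of the three numbers; its distance from compound 1 is beyond the scatter, while its distance from compound 2 is within it. Compound 4, `CC(C)(N)CC(=O)N[C@@H]1CCc2ccccc2N(Cc2ccc(-c3ccccc3-c3nnn(CC(=O)O)n3)cc2)C1=O`, is not yet measured. It differs from compound 3 in one place: 2-(carboxymethyl)-2H-tetrazol-5-yl in place of 1-methyl-1H-tetrazol-5-yl on an aromatic carbon.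

Going by the values given here, two measured steps bear on this. Replacing carboxy with a methyl tetrazole gave a 6.0-fold lower number from compound 1 to compound 3 (0.78 log units; beyond the scatter), and replacing a benzyl tetrazole with the methyl tetrazole gave a 2.0-fold lower number from compound 2 to compound 3 (0.30 log units; within the scatter). Compound 4 keeps a tetrazole but carries a carboxymethyl group on it, so it sits between the carboxy of compound 1 and the substituted tetrazole of compound 2. Compound 4 is therefore expected to give a slightly higher number than compound 3, a step of a 2.0-fold higher number from compound 3 to compound 4 (0.30 log units; within the scatter) in this assay. The estimate for compound 4 is 1 uM, with a range from 0.3 uM to 3 uM.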

Compound 4, concentration for half-maximal effect: 0.2 uM
Estimate against measurement, compound 4: 5.0-fold (0.70 log units) above, outside the stated range (below it).
By their numbers in this assay, from the lowest: compound 4; then compounds 3 and 2 (each within the scatter of the next); then compound 1.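

In this assay, going by these compounds alone, the tetrazole at this place, on an aromatic carbon of a six-membered aromatic ring of carbon only, accepts a substituent carrying a carboxylic acid, and 2-(carboxymethyl)-2H-tetrazol-5-yl gives the first step between tetrazoles that lies beyond the scatter (a 2.5-fold lower number from compound 3 to compound 4 (0.40 log units; beyond the scatter)). The group on the tetrazole therefore matters, as carboxy in place of phenyl on a saturated chain carbon bound to an aromatic nitrogen gives a clear gain (a 5.0-fold lower number from compound 2 to compound 4 (0.70 log units; beyond the scatter)), and the carboxymethyl tetrazole also far outdoes carboxy on the aromatic carbon itself (a 15-fold lower number from compound 1 to compound 4 (1.18 log units; beyond the scatter)). Nothing available explains these shifts.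

Going by these compounds, it remains open whether the gain comes from the carboxymethyl group or from its place on the tetrazole, which 2-methyl-2H-tetrazol-5-yl would separate. On these data alone, it is also open whether a longer chain ending in a carboxylic acid, or the same chain ending in an amine, would behave alike.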